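Lengthening a Saturated Amide Chain on a Shared Core

A few compounds are considered here, and "the series" means these few. Any claim that something is new, unique, unknown or untested is made for them only; others in the source may bear on it.

Two compounds on one shared core differ only in the chain attached through the amide. Compound 1, `CCCCCCCC/C=C/CCCCCCCC(=O)Nc1cc2c(cc1F)c(=O)c(C(=O)OCC)cn2CC`, carries a long chain with one double bond; in a physicochemical assay (on this read-out lower numbers stand for an effect already at smaller amounts and higher numbers for an effect only at larger amounts of compound), compound 1 gives 751 ug/mL. Compound 2, `CCCCCCCCCCCC(=O)Nc1cc2c(cc1F)c(=O)c(C(=O)OCC)cn2CC`, carries a shorter, fully saturated chain. In this assay compound 2 gives "not active" (no number reported), so no number stands for it and it cannot be placed on the scale at all: all that is known is that no effect was recorded. Compound 3, `CCCCCCCCCCCCCCCC(=O)Nc1cc2c(cc1F)c(=O)c(C(=O)OCC)cn2CC`, is compound 2 with butyl in place of hydrogen on a saturated chain carbon, ten or more bonds along the chain from a carbonyl carbon. Within the data shown here, no pair of measured compounds differs by a single change, so no measured step can guide the size of this one. The expectation rests on a single comparison: compound 1, with the longer chain, shows an effect in this assay at 751 ug/mL, whereas compound 2 shows none. A step towards smaller numbers in this assay is thus expected for compound 3, of uncertain size, and it may still end with no effect recorded. Compound 3 is estimated at 1000 ug/mL, within 400 ug/mL to 3000 ug/mL.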

Compound 3, half-maximal effective concentration: "not active" (no number reported)
No number was reported for compound 3; the estimate stays without a comparison.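

In this assay compound 2 and compound 3 are both reported as "not active" with no number, so no step can be read between them. On these data alone, it stays open whether butyl in place of hydrogen on this saturated chain carbon changes the effect at all. No measured evidence bears on this result.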